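The source may report more compounds than this note shows. Statements on the series, on what has been measured and on what is new or still open speak of the compounds shown alone.

Compound 1 `CONc1nc(C#Cc2ccccn2)nc2c1ncn2[C@@H]1O[C@H](CO)[C@@H](O)[C@H]1O` gives 437 nM in an assay on CHO cells for displacement of a labelled ligand from adenosine receptor A1 (Homo sapiens); on this read-out lower numbers stand for stronger inhibition and higher numbers for weaker inhibition.
Compound 2 `CONc1nc(C#Cc2cccnc2)nc2c1ncn2[C@@H]1O[C@H](CO)[C@@H](O)[C@H]1O` gives 255 nM in this assay.
Compound 3 `CNC(=O)[C@H]1O[C@@H](n2cnc3c(NOC)nc(I)nc32)[C@H](O)[C@@H]1O` gives 153 nM in this assay.

Compound 3 thus stands at the lowest of the three numbers; its gap to compound 2 lies within the scatter, while its gap to compound 1 lies beyond it. Compound 4 `CCNC(=O)[C@H]1O[C@@H](n2cnc3c(NOC)nc(I)nc32)[C@H](O)[C@@H]1O` differs from compound 3 by methyl in place of hydrogen on a saturated chain carbon bound to an amide-type nitrogen. Among the measured compounds shown here, the only measured step, a 1.7-fold lower number from compound 1 to compound 2 (0.23 log units; within the scatter), concerns a pyridinyl group on a triple-bonded carbon in another part of the molecule and does not bear on an extension of the methylcarbamoyl chain. For the measured compounds named here, no measured step therefore informs this change, and no shift beyond the scatter is expected in either direction. Compound 4 is expected to give about 150 nM, within a range from 60 nM to 400 nM, an expected step of a 1.0-fold lower number from compound 3 to compound 4 (0.01 log units; within the scatter).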

Compound 4, inhibition constant: 53 nM
For compound 4 the middle estimate is 2.8-fold (0.45 log units) above the measured one, and the stated range ends above it.
By their numbers in this assay, from the lowest: compound 4; then compounds 3, 2 and 1 (each within the scatter of the next, the first and the last beyond it).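

Methylcarbamoyl to ethylcarbamoyl is the only change at this position so far, and in this assay it moves the number beyond the scatter (a 2.9-fold lower number from compound 3 to compound 4 (0.46 log units; beyond the scatter)). A single added methyl on this saturated chain carbon bound to an amide-type nitrogen is therefore enough to give stronger inhibition, though the step is modest. Nothing on hand explains this shift.

As far as these compounds go, whether a longer chain such as propyl, or a cyclopropyl ring, on the amide nitrogen would go further remains open. So does whether ethylcarbamoyl would give a similar step in the pyridinyl compounds.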